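The compounds below may be only part of what the source reports. "The series", "measured", "known", "first", "only" and "open" are said of these compounds alone.

Three compounds from one series share a core and are described here; a fourth has not yet been tested. In a functional assay on HT-29 cells (Homo sapiens) (a lower number here means that less compound is needed, a higher number that more compound is needed for the effect), compound 1 `CN(CCN)C(=O)c1cc(-c2ccccc2)sc1NC(N)=O` gives "not determined" (no result reported) and compound 3 `NC(=O)Nc1sc(-c2ccccc2)cc1C(=O)NC1CCOCC1` gives "not determined" (no result reported), so nothing can be said of their potency. Within the data shown here, compound 2 `NC(=O)Nc1sc(-c2ccc(C(=O)N3CCOCC3)cc2)cc1C(=O)N[C@H]1CCCNC1` is the only one with a number: in this assay compound 2 gives 610 nM. Among the measured compounds shown here, no second measured compound exists to compare with it, so no step between measured compounds can be read, and compound 2 stands alone as the single reference point. Compound 4 `CN(C)c1ccc(-c2cc(C(=O)N[C@H]3CCCNC3)c(NC(N)=O)s2)cc1` has not yet been measured. It differs from compound 2 in one place: dimethylamino in place of (morpholin-4-yl)carbonyl on an aromatic carbon. For the measured compounds named here, the data hold no example of how such a change moves the read-out, and no measured step sets a scale for it. The expected step, a 1.3-fold higher number from compound 2 to compound 4 (0.12 log units; within the scatter), is therefore estimated to stay within the usual scatter, with no clear direction. Compound 4 is expected to give 800 nM in this assay, within a range from 250 nM to 2500 nM.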

Compound 4, half-maximal effective concentration: 90 nM
The estimate for compound 4 lay 8.9-fold (0.95 log units) above the measured number; measured number outside the range, below it.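

Among these compounds, this is the first measured step, and it shows that the read-out is sensitive to what sits on this aromatic carbon, para to a large group. In this assay, dimethylamino in place of (morpholin-4-yl)carbonyl gives a 6.8-fold lower number from compound 2 to compound 4 (0.83 log units; beyond the scatter), so the larger group with its six-membered non-aromatic ring and carbonyl is not required for the effect at this place. Nothing shown bears on the cause of this drop.

A single pair cannot separate the part played by losing the ring or the carbonyl from that of dimethylamino itself, and a plain amine or a morpholin-4-yl group without the carbonyl at this place would be needed to tell these apart. Among the compounds shown here, compound 1 and compound 3 carry no number, so no steps to them can be read.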